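Bromo to hydroxy step in a weakly inhibiting series

This account rests on a few compounds, and the source may have more. Where it says the series, first, only, none or still open, it means among the compounds named here.

- compound 1 `COc1cc(NC(C)CCCNC(=O)NNC(=O)Nc2ccc(Br)cc2)c2ncccc2c1` at 231000 nM
- compound 2 `COc1cc(NC(C)CCCNC(=O)Nc2cc(C(F)(F)F)cc(C(F)(F)F)c2)c2ncccc2c1` at 4700 nM

In a functional assay on MIA PaCa-2 cells (Homo sapiens) for inhibition, read by MTT assay, with a stated time of 72 h (a higher number here means a weaker inhibitor, a lower number a stronger inhibitor), compound 1 gives 231000 nM and stands highest of the two numbers, with compound 2 lower by a margin beyond the scatter. Compound 3 `COc1cc(NC(C)CCCNC(=O)NNC(=O)Nc2ccc(O)cc2)c2ncccc2c1` carries hydroxy in place of bromo on an aromatic carbon para to a large group. For the measured compounds named here, no measured pair shows this exchange, so the direction is uncertain. The estimated 1.3-fold lower number from compound 1 to compound 3 (0.11 log units; within the scatter) is expected to stay within the scatter in this assay and to leave the compound weak. Compound 3 is estimated at 180000 nM and expected between 50000 nM and 500000 nM as a working range.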

Compound 3, half-maximal inhibitory concentration: 142000 nM
Beside the measured number, compound 3's estimate is 1.3-fold (0.10 log units) above it; measured number inside the range.
By their numbers in this assay, from the lowest: compound 2; then compounds 3 and 1 (each within the scatter of the next).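

Hydroxy in place of bromo on this aromatic carbon, para to a large group, gives a 1.6-fold lower number from compound 1 to compound 3 (0.21 log units; within the scatter) in this assay, the first direct reading of this position. The exchange of the 4-bromophenyl for the 4-hydroxyphenyl brings in a hydrogen-bond donor and acceptor, yet the two numbers are not separated and both stay weak. Nothing available accounts for this reading. Going by these compounds, whether an amine or a carboxylic acid at this position would give a step beyond the scatter remains open. So does whether the same exchange reads alike with a longer chain.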